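The source may hold more compounds than are shown below. What is called first, only, known or untested is meant among the compounds shown, and "the series" means these compounds.

In a functional assay on MCF7 cells (Homo sapiens) for cytotoxicity, read by MTT assay, with a stated time of 72 h (a higher number here means a weaker inhibitor, a lower number a stronger inhibitor), compound 1 (`COc1cccc(/C=C2\CCC/C(=C\c3ccc(Cl)cc3)C2=O)c1OC`) gives 10300 nM, compound 2 (`COc1ccccc1/C=C1\CCC/C(=C\c2cccc(OC)c2OC)C1=O`) gives 12000 nM, and compound 3 (`COc1ccc(/C=C2\CCC/C(=C\c3cccc(OC)c3OC)C2=O)cc1`) gives 18600 nM. These three values lie within the scatter of one another, so compound 3 does not stand apart from the other two.

Compound 4 (`COc1ccc(/C=C2\CCC/C(=C\c3cccc(OC)c3OC)C2=O)c(OC)c1`) differs from compound 3 by methoxy in place of hydrogen on an aromatic carbon. Its ring thus carries the methoxy of the 4-methoxyphenyl in compound 3 and also a methoxy where the 2-methoxyphenyl of compound 2 has one.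

The closest evidence is a 1.6-fold higher number from compound 2 to compound 3 (0.19 log units; within the scatter), which exchanges one of these methoxy placements for the other. Two further steps, a 1.2-fold higher number from compound 1 to compound 2 (0.07 log units; within the scatter) and a 1.8-fold higher number from compound 1 to compound 3 (0.26 log units; within the scatter), show the same flat picture when the substituted ring changes. Among the compounds with values here, none of the three steps adds a group to an otherwise unchanged ring, so the series offers no direct precedent for this change.

With every measured step inside the scatter, no shift beyond the scatter is expected in this assay, and the direction is not firmly indicated. The estimate is a 1.3-fold lower number from compound 3 to compound 4 (0.12 log units; within the scatter), which is expected to stay within the scatter. For compound 4 the expected value is 14000 nM, with an estimated range of 6000 nM to 32000 nM.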

Compound 4, half-maximal inhibitory concentration: > 20000 nM
Compound 4: a limit, no number; the forecaster's own chance of this, stated with the estimate: 5%; at least 1.4-fold (0.15 log units) between middle value and limit.
By their numbers in this assay, from the lowest: compounds 1, 2 and 3 (each within the scatter of the next). At a limit, above all of these: compound 4.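

In this assay compound 4 gives > 20000 nM, which is a limit of the assay and not a number. Methoxy in place of hydrogen, ortho to a large group and meta to a methoxy group, is the only change in this series that adds a group to an otherwise unchanged ring, and it can be read only as floors: an at least 1.0-fold higher number from compound 3 to compound 4 (0.03 log units; that floor lies within the scatter) and an at least 1.6-fold higher number from compound 2 to compound 4 (0.22 log units; that floor lies within the scatter). Both floors lie within the scatter, so the added methoxy is not shown to move the number beyond the scatter, though compound 4 alone reaches the limit: the limit of > 20000 nM in this assay, at which 1 of the 4 values shown sits.

From the compounds shown here alone, how far compound 4 lies past the limit stays open, and with it whether the true step from compound 3 lies within or beyond the scatter. Also open, going by these compounds, is whether an amine or a hydroxy group on this same aromatic carbon would leave the number within the scatter of compound 3 or carry it to the limit as methoxy does.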